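Benzyloxy in Place of Phenyl on a Cyclic Sulfonamide Core

The compounds below may be only part of what the source reports. "The series", "measured", "known", "first", "only" and "open" are said of these compounds alone.

Measured so far:
compound 1, `O=C1c2ccccc2N(Cc2ccccc2)S(=O)(=O)N1COCc1ccccc1`, 100000 nM
compound 2, `O=C1c2ccccc2N(Cc2ccccc2Cl)S(=O)(=O)N1Cc1ccccc1Cl`, 40400 nM
compound 3, `O=C1c2ccccc2N(Cc2ccccc2Cl)S(=O)(=O)N1Cc1ccccc1`, 27900 nM

In a functional assay on CCRF-CEM cells (Homo sapiens) for inhibition (a lower number here means that less compound is tolerated, a higher number that more compound is tolerated), compound 3 gives the lowest of the three numbers. Its nearest neighbour is compound 2, and the step of a 1.4-fold lower number from compound 2 to compound 3 (0.16 log units; within the scatter) lies within the scatter. Among the compounds with values here, compound 1 stands furthest from compound 3, and that gap is beyond the scatter; compound 1 is also the only measured compound that carries the benzyloxymethyl chain on the amide-type nitrogen.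

Compound 4, `O=C1c2ccccc2N(Cc2ccccc2Cl)S(=O)(=O)N1COCc1ccccc1`, differs from compound 3 in one place: benzyloxy in place of phenyl on a saturated chain carbon bound to an amide-type nitrogen in a ring. Within the data shown here, no measured step shows this exact change, and the only measured step, between compound 2 and compound 3, concerns a chloro group and does not bear on it. What the numbers of compound 1 and compound 3 show, without being a single-change step, is that the compound carrying the benzyloxymethyl chain gives the higher number. On that basis the step of a 2.2-fold higher number from compound 3 to compound 4 (0.33 log units; beyond the scatter) is expected to go toward a higher number in this assay. For compound 4 the estimate is 60000 nM, with a range from 25000 nM to 150000 nM.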

Compound 4, half-maximal cytotoxic concentration: 22200 nM
For compound 4 the middle estimate is 2.7-fold (0.43 log units) above the measured one; measured number below the stated range.
By their numbers in this assay, from the lowest: compounds 4, 3 and 2 (each within the scatter of the next); then compound 1.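

In this assay, within the data shown here, benzyloxy in place of phenyl at this position gives no step that can be read apart from the scatter (a 1.3-fold lower number from compound 3 to compound 4 (0.10 log units; within the scatter)), and the same holds against the 2-chlorophenyl chain (a 1.8-fold lower number from compound 2 to compound 4 (0.26 log units; within the scatter)). The benzyloxymethyl chain alone therefore does not bring the higher number of compound 1, as compound 4 carries that chain as well. The gap appears instead with chloro in place of hydrogen on an aromatic carbon (a 4.5-fold lower number from compound 1 to compound 4 (0.65 log units; beyond the scatter)), and that change does not read alike on the two cores: the same change on two cores in this assay, a 1.4-fold lower number (0.16 log units; within the scatter) from compound 2 to compound 3 and a 4.5-fold higher number (0.65 log units; beyond the scatter) from compound 4 to compound 1, 6.5-fold (0.81 log units) apart, beyond the scatter of two such steps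

The compounds shown leave open whether an amine or a carboxylic acid at the end of the chain, or a longer chain, would move the number beyond the scatter of compound 4. They also leave open how fluoro or methoxy in place of chloro on that aromatic carbon would read.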